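A larger group on the double bond of compound 2

The source may report more compounds than this note shows. Statements on the series, on what has been measured and on what is new or still open speak of the compounds shown alone.

Measured so far in a functional assay on MCF7 cells (Homo sapiens) for antiproliferative activity, read by CellTiter-Glo, with a stated time of 5 days (a higher number here means a weaker inhibitor, a lower number a stronger inhibitor), compound 1 (`N#Cc1ccc(/C(=C(\c2ccc(/C=C/C(=O)O)cc2)c2ccc3nccn3c2)C2CCC2)c(Cl)c1`) gives 15 nM and compound 2 (`O=C(O)/C=C/c1ccc(/C(=C(\c2ccc(C(F)(F)F)cc2Cl)C2CCC2)c2ccc3nccn3c2)cc1`) gives 5.1 nM as the lower of the two numbers. Within the data shown here, the single measured step is a 2.9-fold lower number from compound 1 to compound 2 (0.47 log units; beyond the scatter) and it comes with trifluoromethyl in place of cyano on an aromatic carbon.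

Compound 3 (`O=C(O)/C=C/c1ccc(/C(=C(\c2ccc(C(F)(F)F)cc2Cl)C2CCC2)c2ccc(-c3cn[nH]c3)cc2)cc1`) has not yet been measured. On a double-bonded chain carbon bound to an aromatic carbon and a double-bonded chain carbon, it carries 4-(1H-pyrazol-4-yl)phenyl in place of the group found in compound 2 (a group of 11 heavy atoms (9 carbon, 2 nitrogen; one five-membered aromatic ring with 2 hetero atoms, one six-membered aromatic ring of carbon only) in place of a group of 9 heavy atoms (7 carbon, 2 nitrogen; one five-membered aromatic ring with 2 hetero atoms, one six-membered aromatic ring with 1 hetero atom), on a double-bonded chain carbon bound to an aromatic carbon and a double-bonded chain carbon). Among the measured compounds shown here, the earlier exchange lies elsewhere in the structure, and compound 3 keeps the trifluoromethyl group of compound 2, so no measured step touches the group that changes here. The data therefore offer no direction, and the modest size of that one step serves only as a rough guide.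

In this assay the estimated step is a 1.6-fold higher number from compound 2 to compound 3 (0.20 log units; within the scatter) and no clear shift is expected, although the uncertainty is wide. Compound 3 is estimated at 8 nM (expected range 1.5 nM to 40 nM).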

Compound 3, half-maximal inhibitory concentration: 16 nM
Beside the measured number, compound 3's estimate is 2.0-fold (0.30 log units) below it; the range from low to high includes it.
By their numbers in this assay, from the lowest: compound 2; then compounds 1 and 3 (each within the scatter of the next).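

In this assay, the exchange of the group on a double-bonded chain carbon bound to an aromatic carbon and a double-bonded chain carbon gives a 3.1-fold higher number from compound 2 to compound 3 (0.50 log units; beyond the scatter). This shows that the number responds to the group at this position, which the earlier step, made elsewhere in the structure, could not show, yet with 4-(1H-pyrazol-4-yl)phenyl in place, compound 3 still gives 16 nM, so this larger group is accepted at a modest cost. The change alters several things at once, as the entering group has one six-membered aromatic ring of carbon only, 1 hydrogen-bond donor and 11 heavy atoms, and no information is available here to tie the shift to any one of these features or to give a reason for it.

It remains open whether the number follows the phenyl or the 1H-pyrazol-4-yl part of the entering group, as no compound shown carries one without the other. Also open, going by these compounds, is how a methyl group on a pyrazole nitrogen, or an amine on the phenyl ring in place of the pyrazole, would read at this position.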